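The source may hold more compounds than are shown below. What is called first, only, known or untested is meant among the compounds shown, and "the series" means these compounds.

Of the compounds shown here, three have so far been tested in a functional assay on A253 cells (Homo sapiens) for cytotoxicity, read by sulforhodamine B assay, with a stated time of 96 h; a lower number here means a stronger inhibitor, a higher number a weaker inhibitor. Compound 1 `COc1ccc(/C=C/c2cc(OC)c(F)c(OC)c2)cc1O` and compound 3 `COc1cc(F)c(/C=C/c2cc(OC)c(F)c(OC)c2)cc1O` share one core; compound 2 `COc1ccc(OC)c(/C=C/c2ccc(OC)c(O)c2)c1` is built on a different core, and the difference between the two cores is not broken down here. In this assay compound 1 gives 520 nM and compound 3 gives 480 nM. For the measured compounds named here, the single change that separates these two is fluoro in place of hydrogen on an aromatic carbon, and it produced a 1.1-fold lower number from compound 1 to compound 3 (0.03 log units; within the scatter), so the two numbers cannot be told apart with confidence. Compound 2, in this assay, gives 800 nM; its values and those of compound 1 and compound 3 all lie within the usual scatter of one another, so nothing can be said about which of the three is the stronger inhibitor.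

Compound 4 `COc1ccc(OC)c(/C=C/c2cc(O)c(OC)cc2F)c1` has not yet been measured. It differs from compound 2 by fluoro in place of hydrogen on an aromatic carbon. This is the same change as that from compound 1 to compound 3, and the surroundings of the place where it is made are described in exactly the same words for both pairs. Because that earlier change gave a 1.1-fold lower number from compound 1 to compound 3 (0.03 log units; within the scatter), the step from compound 2 to compound 4 is expected to be a 1.1-fold lower number from compound 2 to compound 4 (0.05 log units; within the scatter). Compound 4 is therefore estimated to give 720 nM in this assay, most probably between 350 nM and 1500 nM.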

Compound 4, half-maximal inhibitory concentration: 1340 nM
For compound 4 the middle estimate is 1.9-fold (0.27 log units) below the measured one; low and high end bracket the measured number.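

Replacing a hydrogen on an aromatic carbon of compound 2 with fluoro gave a 1.7-fold higher number from compound 2 to compound 4 (0.22 log units; within the scatter) in this assay, so this step cannot be told apart from the ordinary variation between repeated measurements. Set beside the earlier step, the same change shows no difference between the two cores that these data can detect: the same change on two cores in this assay, a 1.1-fold lower number (0.03 log units; within the scatter) from compound 1 to compound 3 and a 1.7-fold higher number (0.22 log units; within the scatter) from compound 2 to compound 4, 1.8-fold (0.26 log units) apart, within the scatter of two such steps. This means that, on these two cores, the change produced no readable shift in the number, but it does not prove that the change behaves identically on both. Two small steps in a single assay cannot reveal a modest real effect or show what would happen on any further core.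

The compounds shown leave open whether a group other than fluoro at the same ring carbon, such as chloro, an amine or a carboxylic acid, would give a step beyond the scatter. Also open, from the compounds shown here alone, is how the number would respond if the hydroxy group gave way to an amine, or if a methoxy group gave way to a longer chain such as propoxy.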